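The compounds below may be only part of what the source reports. "The series", "measured", "known", "first", "only" and "open" are said of these compounds alone.

Compound 3 `COC(=O)c1cncc(NS(=O)(=O)c2cc(Cl)ccc2OC)c1`, tested in an assay on isolated protein for inhibition of alkaline phosphatase, tissue-nonspecific isozyme (Homo sapiens) (a higher number here means a weaker inhibitor, a lower number a stronger inhibitor), gives > 20000 nM, which is a limit of the assay rather than a number. Compound 1 `CNC(=O)c1cncc(NS(=O)(=O)c2cc(Cl)ccc2OC)c1` likewise gives > 20000 nM, again only a limit. The step between them, a step that the two limits leave unreadable from compound 1 to compound 3, therefore has no readable size, a point made plain by the limit of > 20000 nM in this assay, at which 2 of the 3 values shown sit. Compound 2 `COc1ccc(Cl)cc1S(=O)(=O)Nc1cncc(-c2ccccc2C)c1` has "not determined" (no result reported) in this assay. Compound 4 `CCNC(=O)c1cncc(NS(=O)(=O)c2cc(Cl)ccc2OC)c1` differs from compound 3 by ethylamino in place of methoxy on a carbonyl carbon. Among the measured compounds shown here, the only step that bears on this change is the unreadable one between the two limits, so no size in this assay can be drawn from it, and no movement beyond the scatter is expected. Compound 4 is expected to give 20000 nM, between 5000 nM and 80000 nM. The step is thus estimated as a number no higher from compound 3 to compound 4 (the limit leaves the size open).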

Compound 4, half-maximal inhibitory concentration: > 20000 nM
Compound 4: a limit, no number (the forecaster's own chance of this, stated with the estimate: 80%); the middle value sits exactly at the limit.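

No size can be read for the steps linking compound 4 with compound 1 or compound 3, because all three results are limits rather than numbers: the limit of > 20000 nM in this assay, at which 3 of the 4 values shown sit.

The compounds shown leave open what change to the shared core, if any, would give a number rather than a limit.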